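Alkyl imine swap on compound 1: isopropyl to butyl

The compounds below may be only part of what the source reports. "The series", "measured", "known", "first", "only" and "open" are said of these compounds alone.

Measured compounds:
compound 1, `C/C(=N\C(C)C)c1c(O)c2ccccc2[nH]c1=O`: in an assay on isolated protein for inhibition of myosin-2 (Bos taurus), read by spectrophotometry, with a stated time of 24 min (a lower number here means a stronger inhibitor, a higher number a weaker inhibitor), compound 1 gives >= 100000 nM, a limit of the measurement rather than a number.
compound 2, `C/C(=N\Nc1ccccc1)c1c(O)c2ccccc2oc1=O`: in this assay compound 2 gives 27000 nM.

Compound 1 stands at the weak end of the two numbers shown: its value is only a limit (the limit of >= 100000 nM in this assay, at which 1 of the 2 values shown sits), so no true inhibitory concentration is known for it. Among the compounds with values here, compound 2 carries a different core and a different imine substituent, so no single step links the two, and its value shows only that a number was reached there.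

Compound 3, `CCCC/N=C(\C)c1c(O)c2ccccc2[nH]c1=O`, is not yet measured. It differs from compound 1 by butyl in place of isopropyl on a double-bonded nitrogen. With no measured step of this kind in the series, the change is expected to stay within the usual scatter, with no clear direction. Compound 3 is therefore expected to give about 100000 nM, plausibly between 30000 nM and 300000 nM. The expected step is a number no higher from compound 1 to compound 3 (the limit leaves the size open), and a limit-only result for compound 3 is likely.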

Compound 3, half-maximal inhibitory concentration: >= 100000 nM
Compound 3: only a limit was reported; the forecaster's own chance of this, stated with the estimate: 65%; the middle value sits exactly at the limit.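

In this assay no step can be read between compound 1 and compound 3, because both results are limits: the limit of >= 100000 nM in this assay, at which 2 of the 3 values shown sit.

The compounds shown leave open how compound 1 and compound 3 truly compare, and whether any alkyl group on this nitrogen gives a measurable inhibitory concentration on their shared core.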